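A few compounds are considered here, and "the series" means these few. Any claim that something is new, unique, unknown or untested is made for them only; others in the source may bear on it.

Within the data shown here, in an assay on Sf21 cells for inhibition of ubiquitin carboxyl-terminal hydrolase 7 (Homo sapiens), read by spectrophotometry, with stated times of 30 min and 2 h (on this read-out higher numbers stand for weaker inhibition and lower numbers for stronger inhibition), compound 3 `COC(=O)c1ccc(CN2CCC(O)(Cn3cnc4c(cnn4-c4ccc(F)cc4)c3=O)CC2)cc1` gives 4500 nM, the only number in this small set. Compound 1 `O=c1c2cnn(-c3ccc(F)cc3)c2ncn1CC1(O)CCN(Cc2ccncc2)CC1` gives "not determined" (no result reported) and compound 2 `Cc1ccccc1CN1CCC(O)(Cn2cnc3c(cnn3-c3ccc(F)cc3)c2=O)CC1` gives "not determined" (no result reported) in this assay, so these two, which share the same core, have no reported result, and compound 3 stands alone as the reference point. Compound 4 `O=c1c2cnn(-c3ccc(F)cc3)c2ncn1CC1(O)CCN(Cc2ccc(Cl)cc2Cl)CC1` differs from compound 3 in one place: 2,4-dichlorophenyl in place of 4-(methoxycarbonyl)phenyl on a saturated chain carbon bound to an amine nitrogen in a ring. Among the measured compounds shown here, no step between two measured compounds is available to guide the outlook, which therefore rests on compound 3 alone. The step of a 1.5-fold lower number from compound 3 to compound 4 (0.18 log units; within the scatter) is expected to be small, in either direction, and not clearly beyond the usual scatter. Compound 4 is expected to give 3000 nM in this assay, with a plausible range from 800 nM to 12000 nM.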

Compound 4, half-maximal inhibitory concentration: 3300 nM
Compound 4: the middle estimate sits 1.1-fold (0.04 log units) below what was measured, within the range that was stated.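

In this assay, replacing 4-(methoxycarbonyl)benzyl with 2,4-dichlorobenzyl gives a 1.4-fold lower number from compound 3 to compound 4 (0.13 log units; within the scatter), so these two groups, which share a phenyl ring but carry different substituents, cannot be told apart at this place. Nothing available explains this lack of separation. Steps involving compound 1 and compound 2 cannot be read, as neither has a reported result. Still open, as far as these compounds go, is whether a carboxylic acid or an amine on the phenyl ring, or a longer chain in place of the benzyl carbon, would move the number beyond the scatter.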